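The compounds below may be only part of what the source reports. "The series", "measured", "known", "first", "only" and "open" are said of these compounds alone.

Working notes on the series. Compound 1 `O=C(C1=CC(=O)c2ccccc2C1=O)c1ccc(Cl)cc1` and compound 2 `O=C(C1=CC(=O)c2ccccc2C1=O)c1ccc(F)cc1` share one core, and in a functional assay on WHCO1 cells (Homo sapiens) for cytotoxicity, read by MTT assay, with a stated time of 24 h (on this read-out lower numbers stand for stronger inhibition and higher numbers for weaker inhibition), compound 1 gives 72900 nM while compound 2 gives 74900 nM. The change between them, (chloro in place of fluoro on an aromatic carbon), made a 1.0-fold lower number from compound 2 to compound 1 (0.01 log units; within the scatter). Compound 3 `O=C1C=C(C(O)c2cccc(F)c2)C(=O)c2ccccc21` has a different core; how the two cores differ is not broken down here. In this assay compound 3 gives 5500 nM, the lowest of the three numbers, with both other compounds beyond the scatter from it.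

Compound 4 `O=C1C=C(C(O)c2cccc(Cl)c2)C(=O)c2ccccc21` is not yet measured. It differs from compound 3 by chloro in place of fluoro on an aromatic carbon. This is the same kind of change as that from compound 2 to compound 1, not the same one: there the chloro sits para to a large group, here meta to a large group, and the core differs as well.

In this assay the expected step is no change at the digits printed from compound 3 to compound 4 (within the scatter), because a 1.0-fold lower number from compound 2 to compound 1 (0.01 log units; within the scatter) was within the scatter. Compound 4 is therefore expected to give about 5500 nM, plausibly between 2500 nM and 12000 nM.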

Compound 4, half-maximal inhibitory concentration: 7300 nM
Compound 4: middle estimate off by 1.3-fold (0.12 log units), on the low side, within the range that was stated.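

In this assay, chloro in place of fluoro gives a 1.3-fold higher number from compound 3 to compound 4 (0.12 log units; within the scatter), and this step agrees with the one seen on the other core: the same change on two cores in this assay, a 1.0-fold lower number (0.01 log units; within the scatter) from compound 2 to compound 1 and a 1.3-fold higher number (0.12 log units; within the scatter) from compound 3 to compound 4, 1.4-fold (0.13 log units) apart, within the scatter of two such steps. Within these two pairs, the exchange therefore carries from one core to the other as a step within the scatter, which gives no sign that the core alters its outcome. This does not show that the exchange would stay this small on any further core, and since the halogen's position differs along with the core, the two pairs cannot separate those two differences.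

The compounds shown leave open whether a group other than these two halogens on that ring, such as an amine, a methoxy group or a carboxylic acid, would give a step beyond the scatter. They also leave open how a plain phenyl ring without any halogen would compare on either core.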